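Trimming a methoxy from compound 1: what to expect

The source may report more compounds than this note shows. Statements on the series, on what has been measured and on what is new or still open speak of the compounds shown alone.

Of the compounds shown here, three sharing one core have been measured in a functional assay on OVCAR-8 cells (Homo sapiens) for inhibition, read by sulforhodamine B assay, with a stated time of 48 h; a higher number here means a weaker inhibitor of growth, a lower number a stronger inhibitor of growth. Compound 1 `COc1ccc(CNc2nc3cc(N)cc(N)c3nc2-c2ccccc2)cc1OC` gives 33900 nM; compound 2 `CCOC(=O)[C@H](CCC(=O)O)NC(=O)c1ccc(Sc2nc3cc(N)cc(N)c3nc2-c2ccccc2)cc1` gives 39800 nM; compound 3 `COc1cc(CNc2nc3cc(N)cc(N)c3nc2-c2ccccc2)cc(OC)c1OC` gives 14800 nM. Compound 1 stands second highest of the three numbers: its nearest neighbour is compound 2, whose value lies within the scatter of it, while the furthest value lies a 2.3-fold lower number from compound 1 to compound 3 (0.36 log units; beyond the scatter). Going by the values given here, that change, methoxy in place of hydrogen on an aromatic carbon, is the only one-place step yet measured.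

Compound 4 `COc1ccc(CNc2nc3cc(N)cc(N)c3nc2-c2ccccc2)cc1` is the next to be measured. It differs from compound 1 by hydrogen in place of methoxy on an aromatic carbon, or, cut one bond further out, 3,4-dimethoxyphenyl to 4-methoxyphenyl. Among the compounds with values here, the one measured step bears on it only loosely, since it went the other way, adding a methoxy, and read a 2.3-fold lower number from compound 1 to compound 3 (0.36 log units; beyond the scatter). Removing a methoxy might therefore be expected to raise the number somewhat in this assay, though a single step is thin ground, and a result within the scatter would not surprise. Compound 4 is estimated at 45000 nM, with a range from 15000 nM to 150000 nM. That estimate means an expected step of a 1.3-fold higher number from compound 1 to compound 4 (0.12 log units; within the scatter).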

Compound 4, concentration for total growth inhibition: 39800 nM
For compound 4 the middle estimate is 1.1-fold (0.05 log units) above the measured one; the range from low to high includes it.
By their numbers in this assay, from the lowest: compound 3; then compounds 1, 2 and 4 (each within the scatter of the next).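

Replacing this methoxy, which sits ortho to a methoxy group and meta to a large group, with hydrogen gives a 1.2-fold higher number from compound 1 to compound 4 (0.07 log units; within the scatter), so in this assay it can be removed with no change that the measurement can resolve. The only earlier one-place step was an addition to the same ring, a 2.3-fold lower number from compound 1 to compound 3 (0.36 log units; beyond the scatter), so the two changes now shown on this ring do not behave alike: adding that methoxy moves the number beyond the scatter, while removing this one does not. Nothing available explains this difference between the two steps.

The compounds shown leave open whether the methoxy that remains on compound 4 could also be replaced by hydrogen without a change beyond the scatter. They also leave open how a hydroxyl group, a fluorine atom or a longer chain such as ethoxy would read in place of the removed methoxy, and so whether this position accepts other groups as well as it accepts hydrogen.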